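Methyl to Trifluoromethoxy on the Shared Core

The source may hold more compounds than are shown below. What is called first, only, known or untested is meant among the compounds shown, and "the series" means these compounds.

Three compounds share one core. Compound 1 `Cc1ccc2nc(-c3ccccc3N(C)C)[nH]c(=O)c2c1` in a functional assay on HCT-15 cells (Homo sapiens) for cytotoxicity, read by MTT assay, with a stated time of 2 days (on this read-out lower numbers stand for stronger inhibition and higher numbers for weaker inhibition), gives only a limit of the assay, > 50000 nM, not a number. Compound 2 `CN(C)c1ccc2nc(-c3cccc4ccccc34)[nH]c(=O)c2c1` gives 460 nM in this assay. Compound 3 `Cc1ccc2c(=O)[nH]c(-c3ccccc3C)nc2c1` gives 11900 nM, the higher of the two numbers; its nearest neighbour, compound 2, sits far below it, well beyond the usual scatter.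

Compound 4 `Cc1ccc2c(=O)[nH]c(-c3ccccc3OC(F)(F)F)nc2c1` differs from compound 3 in one place: trifluoromethoxy in place of methyl on an aromatic carbon. Among the compounds with values here, no pair of measured compounds shows this kind of change, so there is nothing to lean on. The step is expected to be small, perhaps not beyond the scatter, as a 1.5-fold lower number from compound 3 to compound 4 (0.17 log units; within the scatter) sets out. Compound 4 is therefore expected to give about 8000 nM in this assay, with a likely range from 2000 nM to 40000 nM.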

Compound 4, half-maximal inhibitory concentration: 15900 nM
The estimate for compound 4 lay 2.0-fold (0.30 log units) below the measured number, within the range that was stated.
By their numbers in this assay, from the lowest: compound 2; then compounds 3 and 4 (each within the scatter of the next). At a limit, above all of these: compound 1.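

Trifluoromethoxy in place of methyl on this aromatic carbon gives a 1.3-fold higher number from compound 3 to compound 4 (0.13 log units; within the scatter) in this assay, so the two compounds cannot be told apart. This place, ortho to a large group, therefore accepts a much larger group with no difference that can be read on this scale. Both compounds give real numbers, and neither sits at the limit of the assay: the limit of > 50000 nM in this assay, at which 1 of the 4 values shown sits.

On these data alone, whether an amine or a carboxylic acid at this place would move the number stays open. One pair also cannot show whether the same swap would read alike on other compounds.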